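Tetrazole in place of the terminal acid on compound 1

The compounds below may be only part of what the source reports. "The series", "measured", "known", "first", "only" and "open" are said of these compounds alone.

Measured compounds:
compound 1 `CCCc1c(COc2ccc(C(=O)CCCC(=O)O)cc2)ccc(C(C)=O)c1O`, 9.5 mg/kg
compound 2 `CCc1c(COc2ccc(C(=O)CC(C)(C)CC(=O)O)cc2)ccc(C(C)=O)c1O`, 1.4 mg/kg
compound 3 `CCCCc1c(COc2ccc(C(=O)CCCCC(=O)O)cc2)ccc(C(C)=O)c1O`, 9.1 mg/kg

All three were run in an in vivo functional assay on the whole organism (Rattus norvegicus) with cysteinyl leukotriene receptor (Homo sapiens) as the target; on this read-out lower numbers stand for an effect already at smaller amounts and higher numbers for an effect only at larger amounts of compound. Compound 1 gives the highest number of the three at 9.5 mg/kg. Compound 3 sits within the scatter of compound 1, so nothing separates them; compound 2 lies beyond the scatter on the lower side, and that gap is the only clear difference in the set.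

Compound 4 `CCCc1c(COc2ccc(C(=O)CCCCCCc3nnn[nH]3)cc2)ccc(C(C)=O)c1O` is not yet measured. It differs from compound 1 as follows: 3-(1H-tetrazol-5-yl)propyl in place of carboxy on a saturated chain carbon, three bonds along the chain from a carbonyl carbon. Among the compounds with values here, no step of this kind is available among the measured compounds, so the size of the step rests on judgment alone. The expectation is a modest move toward a lower number in this assay, of a size that may not clear the scatter: the step from compound 1 to compound 4 is estimated at a 1.6-fold lower number from compound 1 to compound 4 (0.20 log units; within the scatter). For compound 4 the estimate is 6 mg/kg, with a range from 2 mg/kg to 20 mg/kg.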

Compound 4, dose for half-maximal effect: 8.5 mg/kg
Beside the measured number, compound 4's estimate is 1.4-fold (0.15 log units) below it; measured number inside the range.
By their numbers in this assay, from the lowest: compound 2; then compounds 4, 3 and 1 (each within the scatter of the next).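

In this assay, replacing carboxy with 3-(1H-tetrazol-5-yl)propyl on a saturated chain carbon, three bonds along the chain from a carbonyl carbon, gives a 1.1-fold lower number from compound 1 to compound 4 (0.05 log units; within the scatter). On the core of compound 1, this place therefore accepts a group of 8 heavy atoms with a five-membered aromatic ring in place of a group of 3 heavy atoms with no ring, and the read-out holds without any carboxy in the molecule. Nothing available accounts for this outcome.

The change combines a new ring with a longer chain, so 1H-tetrazol-5-yl directly in place of carboxy, or carboxy carried on a 6-carbon chain extension, would be needed to separate the two contributions. Also open, as far as these compounds go, is how an acylsulfonamide at this place would read in this assay.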